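Methylcarbamoyl for cyclohexylamino: a step near the assay limit

This account rests on a few compounds, and the source may have more. Where it says the series, first, only, none or still open, it means among the compounds named here.

In a physicochemical assay for solubility, read by nephelometry (on this read-out higher numbers stand for higher solubility and lower numbers for lower solubility), compound 1 (`CN(C)c1cc(CN2C(=O)N(c3ccc(SC(F)(F)F)cc3)C(=O)C2(C)C)ccn1`) gives < 0.022 ug/mL and this is a limit, not a number. Compound 2 (`CC1(C)C(=O)N(c2ccc(SC(F)(F)F)cc2)C(=O)N1Cc1ccnc(F)c1`) gives 0.032 ug/mL as a measured number. Compound 3 (`CC1(C)C(=O)N(c2ccc(SC(F)(F)F)cc2)C(=O)N1Cc1ccnc(NC2CCCCC2)c1`) gives < 0.025 ug/mL and this too is a limit.

Compound 4 (`CNC(=O)c1cc(CN2C(=O)N(c3ccc(SC(F)(F)F)cc3)C(=O)C2(C)C)ccn1`) carries methylcarbamoyl in place of cyclohexylamino on an aromatic carbon. The measured steps at that carbon are an at least 1.4-fold higher number from compound 1 to compound 2 (0.16 log units; that floor lies within the scatter) and an at least 1.2-fold lower number from compound 2 to compound 3 (0.10 log units; that floor lies within the scatter) and a step that the two limits leave unreadable from compound 1 to compound 3. The floors of the first two lie within the scatter, and the third has no readable size. Among the compounds with values here, no measured step at this carbon therefore gives a firm size for the new change. Within the data shown here, the only number available is the value of compound 2 (0.032 ug/mL), so the expectation stays close to it in this assay. The expected result is a small step, upward if there is one, possibly no more than the scatter: an at least 1.6-fold higher number from compound 3 to compound 4 (0.20 log units; that floor lies within the scatter). For compound 4 the estimated value is 0.04 ug/mL with an expected range of 0.015 ug/mL to 0.15 ug/mL.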

Compound 4, solubility: < 0.023 ug/mL
Compound 4 was reported as a limit; the forecaster's own chance of this, stated with the estimate: 35%; middle value at least 1.7-fold (0.24 log units) from the limit.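

In this assay compound 4 gives < 0.023 ug/mL, and this value is a limit. With methylcarbamoyl, three of the four groups shown at this carbon now end at a limit, with or without a six-membered non-aromatic ring in the group, and the exception is fluoro in compound 2. Within the data shown here, the one readable new step is an at least 1.3-fold lower number from compound 2 to compound 4 (0.14 log units; that floor lies within the scatter), while the steps to compound 4 from the two other limit compounds cannot be read.

The compounds shown leave open how the three limit compounds stand relative to one another, and whether any real gap separates them from the fluoro compound. Also open, as far as these compounds go, is whether a carboxylic acid or a morpholine at this carbon would give a measured number in this assay rather than a limit.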